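Ring expansion on the sulfonamide side chain

The source may report more compounds than this note shows. Statements on the series, on what has been measured and on what is new or still open speak of the compounds shown alone.

Compound 1 `NC(=O)[C@@H](CCC(F)(F)F)N(CC1COC1)S(=O)(=O)c1ccc(Cl)cc1`: 2.5
Compound 2 `CC1(C)CO[C@@H]1CN([C@H](CCC(F)(F)F)C(N)=O)S(=O)(=O)c1ccc(Cl)cc1`: 3.9
Compound 3 `CC1(C)CO[C@H]1CN([C@H](CCC(F)(F)F)C(N)=O)S(=O)(=O)c1ccc(Cl)cc1`: 3.8

Compound 3 stands second highest of the three in a physicochemical assay for lipophilicity, read by HPLC, measured as octanol-water partition, at pH 7.4; on this read-out higher numbers stand for higher lipophilicity and lower numbers for lower lipophilicity. Its nearest neighbour is compound 2, and those two differ only in configuration as drawn (the fact that compounds 2 and 3 differ only in the configuration as drawn), with the step of a number 0.10 log units lower from compound 2 to compound 3 (within the scatter) lying within the scatter. Compound 1 is far below, as the step of a number 1.30 log units higher from compound 1 to compound 3 (beyond the scatter) shows.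

Compound 4 `NC(=O)[C@@H](CCC(F)(F)F)N(C[C@@H]1CCCOC1)S(=O)(=O)c1ccc(Cl)cc1` has not yet been measured. The change from compound 3 to compound 4 is oxan-3-yl in place of 3,3-dimethyloxetan-2-yl on a saturated chain carbon bound to a sulfonamide nitrogen. The two measured steps that bear on it are a number 1.40 log units higher from compound 1 to compound 2 (beyond the scatter) and a number 1.30 log units higher from compound 1 to compound 3 (beyond the scatter), both large, and both tell how strongly the dimethyloxetane raises the read-out over a plain oxetane. Compound 4 keeps the same heavy-atom count in the ring-bearing group but loses the two methyls in favour of a six-membered ring, so only a modest fall is expected: the estimated step is a number 0.40 log units lower from compound 3 to compound 4 (beyond the scatter). For compound 4 in this assay the estimate is 3.4, expected between 2.9 and 3.9.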

Compound 4, distribution coefficient: 3.7
Estimate against measurement, compound 4: 0.30 log units below; low and high end bracket the measured number.
By their numbers in this assay, from the lowest: compound 1; then compounds 4, 3 and 2 (each within the scatter of the next).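

In this assay, oxan-3-yl and 3,3-dimethyloxetan-2-yl cannot be told apart at this place on a saturated chain carbon bound to a sulfonamide nitrogen, with a number 0.10 log units lower from compound 3 to compound 4 (within the scatter) and a number 0.20 log units lower from compound 2 to compound 4 (within the scatter) as the two readings. The new group thus stands level with both members of a pair: the fact that compounds 2 and 3 differ only in the configuration as drawn. Against oxetan-3-yl, the oxan-3-yl group gives a number 1.20 log units higher from compound 1 to compound 4 (beyond the scatter) as a large step, so among these four compounds compound 1 alone stands apart, and the same atoms arranged as a six-membered ring instead of a four-membered ring with two methyls leave the read-out unmoved.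

The compounds shown leave open how the other configuration of the oxan-3-yl stereocentre would read. They also leave open whether a ring bearing an amine or a carboxylic acid at this place would stay level with compounds 2, 3 and 4.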